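From an Anilide to a Benzylamide in One Step

The source may report more compounds than this note shows. Statements on the series, on what has been measured and on what is new or still open speak of the compounds shown alone.

Compound 3 `COc1cc(-c2nnc(SCC(=O)Nc3ccccc3C)n2N)cc(OC)c1OC` carries the shared core with an amide whose nitrogen bears a 2-methylphenyl group. In a functional assay on PC-3 cells (Homo sapiens) for antiproliferative activity, read by MTT assay, with a stated time of 48 h (a lower number here means a stronger inhibitor, a higher number a weaker inhibitor), compound 3 gives > 100000 nM, which is a limit of the assay rather than a number. Compound 1 `COc1cc(-c2nnc(SCC(=O)c3ccc(Br)cc3)n2N)cc(OC)c1OC` likewise gives > 100000 nM in this assay, again only a limit. Compound 2 `COc1cc(-c2nnc(SCC(=O)Nc3ccccc3)n2N)cc(OC)c1OC` gives 37900 nM in this assay. Two steps can be read: an at least 2.6-fold lower number from compound 1 to compound 2 (0.42 log units; beyond the scatter) and an at least 2.6-fold higher number from compound 2 to compound 3 (0.42 log units; beyond the scatter), whereas a step that the two limits leave unreadable from compound 1 to compound 3. As far as these compounds go, both readable steps are bounded by the limit of > 100000 nM in this assay, at which 2 of the 3 values shown sit, so their true size stays open.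

Compound 4 `COc1cc(-c2nnc(SCC(=O)NCc3ccc(C)cc3)n2N)cc(OC)c1OC` differs from compound 3 in one place: 4-methylbenzyl in place of 2-methylphenyl on an amide-type nitrogen. Among the compounds with values here, none of the measured steps changes the link between the amide nitrogen and the ring, so no step bears directly on this change. The nearest is an at least 2.6-fold higher number from compound 2 to compound 3 (0.42 log units; beyond the scatter), where a methyl on the ring gave a weaker compound; compound 4 keeps a methyl, but as a 4-methylbenzyl rather than a 2-methylphenyl, so that step offers only weak guidance.

Compound 4 is therefore expected to sit near the limit again, with an estimate of 80000 nM in this assay, ranging from 25000 nM to 250000 nM. The expected step is an at least 1.2-fold lower number from compound 3 to compound 4 (0.09 log units; that floor lies within the scatter), hardly beyond the scatter.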

Compound 4, half-maximal inhibitory concentration: 92800 nM
Compound 4: middle estimate off by 1.2-fold (0.06 log units), on the low side; low and high end bracket the measured number.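

Within the data shown here, compound 4 is the first compound here with a benzyl group rather than a phenyl ring on the amide-type nitrogen, and in this assay it gives a measured number rather than a limit. Going from phenyl to 4-methylbenzyl at this place gives a 2.4-fold higher number from compound 2 to compound 4 (0.39 log units; beyond the scatter), so among the compounds that can be read, the simple anilide remains the stronger of the two. The other comparisons say much less, with an at least 1.0-fold lower number from compound 3 to compound 4 (0.03 log units; that floor lies within the scatter) and an at least 1.0-fold lower number from compound 1 to compound 4 (0.03 log units; that floor lies within the scatter), and neither separates the compounds, because the true values of compound 1 and compound 3 stay unknown: the limit of > 100000 nM in this assay, at which 2 of the 4 values shown sit.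

The step from compound 2 to compound 4 adds both a methyl and a benzyl-type link, and the compounds shown cannot say which of the two accounts for it; a plain benzyl group on the amide-type nitrogen would pull them apart. Also open, as far as these compounds go, is whether a longer chain such as 2-phenylethyl, or an aliphatic group such as cyclohexyl on that nitrogen, would follow compound 4 or compound 2.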